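The compounds below may be only part of what the source reports. "The series", "measured", "known", "first", "only" and "open" are said of these compounds alone.

Compound 2 `COc1cc2ncnc(NNC(=S)NC(=O)c3ccc(F)cc3)c2cc1OC` was tested in a functional assay on CNE-2 cells (Homo sapiens) for cytotoxicity, read by MTT assay, with a stated time of 72 h (a higher number here means a weaker inhibitor, a lower number a stronger inhibitor), where it gives 16100 nM. Among the three compounds measured so far it sits in the middle: compound 3 `Cc1ccc(C(=O)NC(=S)NNc2ncnc3ccccc23)cc1` gives 17200 nM and compound 1 `COc1cc2ncnc(NNC(=S)NC(=O)c3ccccc3C)c2cc1OC` gives 10500 nM, and both of these lie within the scatter of compound 2, so no order among the three can be claimed. Compound 4 `COc1cc2ncnc(NNC(=S)NC(=O)c3cccc(Cl)c3)c2cc1OC` differs from compound 2 in one place: 3-chlorophenyl in place of 4-fluorophenyl on a carbonyl carbon. Among the compounds with values here, the only measured step at the same place, on the carbonyl carbon, is a 1.5-fold higher number from compound 1 to compound 2 (0.19 log units; within the scatter), which changed nothing beyond the scatter. No step beyond the scatter is therefore expected for the 3-chlorophenyl group either, giving an estimated 1.2-fold lower number from compound 2 to compound 4 (0.06 log units; within the scatter). Compound 4 is expected to give about 14000 nM, with a likely range from 6500 nM to 30000 nM.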

Compound 4, half-maximal inhibitory concentration: 7460 nM
Compound 4: middle estimate off by 1.9-fold (0.27 log units), on the high side, and the stated range covers the measured number.
By their numbers in this assay, from the lowest: compounds 4, 1, 2 and 3 (each within the scatter of the next, the first and the last beyond it).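

In this assay, this position on a carbonyl carbon gives its first step beyond the scatter: 3-chlorophenyl in place of 4-fluorophenyl (a 2.2-fold lower number from compound 2 to compound 4 (0.33 log units; beyond the scatter)). The same group in place of 2-methylphenyl stays within it (a 1.4-fold lower number from compound 1 to compound 4 (0.15 log units; within the scatter)), so the aryl group here can shift the number, but only modestly, and not with every swap. Nothing available explains this difference. On these data alone, whether the chlorine itself or its placement on the ring matters stays open, as does how a pyridine ring or a longer alkyl chain would read here.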